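Amide-side aryl variation across the shared core

A few compounds are considered here, and "the series" means these few. Any claim that something is new, unique, unknown or untested is made for them only; others in the source may bear on it.

Measured so far:
compound 1, `COc1ccc2c(=O)c(/C=C/C(=O)Nc3cccc(Cl)c3)coc2c1`: 470 nM in a functional assay on A549 cells (Homo sapiens) for inhibition, read by MTT assay, with a stated time of 48 h; on this read-out higher numbers stand for weaker inhibition and lower numbers for stronger inhibition
compound 2, `COc1ccc2c(=O)c(/C=C/C(=O)NCc3ccc(F)cc3)coc2c1`: > 100000 nM, a limit of the assay
compound 3, `COc1ccc2c(=O)c(/C=C/C(=O)Nc3ccc(Cl)cc3)coc2c1`: > 100000 nM, a limit of the assay

Compound 3 stands only as a limit in this assay; it gives > 100000 nM and no number. Compound 4, `COc1ccc2c(=O)c(/C=C/C(=O)Nc3ccc(F)cc3)coc2c1`, differs from compound 3 by fluoro in place of chloro on an aromatic carbon. Among the compounds with values here, no measured step covers this exact exchange. Within the data shown here, the steps that bear on the amide nitrogen substituent are an at least 210-fold higher number from compound 1 to compound 3 (2.32 log units; beyond the scatter) and an at least 210-fold higher number from compound 1 to compound 2 (2.32 log units; beyond the scatter), both large, while a step that the two limits leave unreadable from compound 2 to compound 3 cannot be read. Compound 2 and compound 3 both sit at the limit of > 100000 nM in this assay, at which 2 of the 3 values shown sit. Compound 4 is therefore expected to remain at or near that limit, a step of a number no higher from compound 3 to compound 4 (the limit leaves the size open). The estimate for compound 4 is 100000 nM, with a range from 20000 nM to 300000 nM.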

Compound 4, half-maximal inhibitory concentration: 26800 nM
For compound 4 the middle estimate is 3.7-fold (0.57 log units) above the measured one; the measured number falls inside the stated range.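

In this assay a 4-substituted phenyl on the amide nitrogen now gives a readable value, so this position is not uniformly at the limit: fluoro in place of chloro gives an at least 3.7-fold lower number from compound 3 to compound 4 (0.57 log units; beyond the scatter), and 4-fluorophenyl in place of 4-fluorobenzyl gives an at least 3.7-fold lower number from compound 2 to compound 4 (0.57 log units; beyond the scatter). The 3-chlorophenyl amide nevertheless remains clearly ahead, with a 57-fold higher number from compound 1 to compound 4 (1.76 log units; beyond the scatter). The first two steps give only a minimum size because each starts from a limit: the limit of > 100000 nM in this assay, at which 2 of the 4 values shown sit. Still open, on these data alone, is whether an amine or carboxylic acid on this phenyl ring, or 3-fluorophenyl on the amide nitrogen, would shift the value.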